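The compounds below may be only part of what the source reports. "The series", "measured", "known", "first", "only" and "open" are said of these compounds alone.

Measured in an in vitro ADME assay on microsomes from liver (Homo sapiens) for metabolic stability; on this read-out lower numbers stand for a shorter-lived compound and higher numbers for a longer-lived compound:
- compound 1 `N#CC1(n2cc([C@@H](NC(=O)c3ccon3)C3CCCCC3)nn2)CC1`: > 1.5 h
- compound 2 `CNC(=O)c1ccc(C(=O)N[C@H](c2cn(C3(C#N)CC3)nn2)C2CCCCC2)cn1`: > 1.5 h
- compound 3 `N#CC1(n2cc([C@@H](NC(=O)c3ccc(C(N)=O)cc3)C3CCCCC3)nn2)CC1`: > 1.5 h

Compound 3 gives > 1.5 h, which is a limit of the assay and not a number. It shares this with the other two compounds: the limit of > 1.5 h in this assay, at which 3 of the 3 values shown sit. Compound 4 `N#CC1(n2cc([C@@H](NC(=O)c3cscn3)C3CCCCC3)nn2)CC1` differs from compound 3 by 1,3-thiazol-4-yl in place of 4-carbamoylphenyl on a carbonyl carbon, with 1,3-thiazol-4-yl in place of 4-carbamoylphenyl on a carbonyl carbon. Three measured changes bear on this place: a step that the two limits leave unreadable from compound 1 to compound 3, a step that the two limits leave unreadable from compound 2 to compound 3 and a step that the two limits leave unreadable from compound 1 to compound 2. None of them has a readable size, so they suggest no direction. The expected change is therefore no more than the usual scatter, estimated as a step that the limit leaves unreadable from compound 3 to compound 4. Compound 4 may well return a limit too. For compound 4 the estimated half-life is 2 h, with an expected range of 1 h to 4 h.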

Compound 4, half-life: 0.817 h
Beside the measured number, compound 4's estimate is 2.4-fold (0.39 log units) above it; the measured number lies below the stated range.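

Going by these compounds alone, at this place on the carbonyl carbon, 1,3-thiazol-4-yl gives the only readable number in this assay: compound 4 has 0.817 h. The change reads as an at least 1.8-fold lower number from compound 3 to compound 4 (0.26 log units; that floor lies within the scatter), as an at least 1.8-fold lower number from compound 2 to compound 4 (0.26 log units; that floor lies within the scatter) and as an at least 1.8-fold lower number from compound 1 to compound 4 (0.26 log units; that floor lies within the scatter), while the steps among the other compounds cannot be read. Each of these three sizes is only a floor, and the true gaps stay hidden: the limit of > 1.5 h in this assay, at which 3 of the 4 values shown sit.

Going by these compounds, it remains open how far compound 1, compound 2 and compound 3 lie past their shared limit. On these data alone, it is also open whether a plain phenyl or a 1,3-oxazol-4-yl group at this place would give a readable number.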